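Swapping the aryl group on a bicyclic glutamate receptor ligand

The compounds below may be only part of what the source reports. "The series", "measured", "known", "first", "only" and "open" are said of these compounds alone.

Measured so far:
compound 1 `N[C@]1(C(=O)O)[C@H]2[C@@H](C[C@H]1OCc1cc(Cl)cc(Cl)c1)[C@]2(F)C(=O)O` — 5.61 nM
compound 2 `N[C@]1(C(=O)O)[C@H]2[C@@H](C[C@H]1OCc1c(Cl)cccc1Cl)[C@]2(F)C(=O)O` — 4.3 nM

Both compounds were tested in an assay on CHO cells for binding affinity to metabotropic glutamate receptor 2 (Rattus norvegicus); on this read-out higher numbers stand for weaker inhibition and lower numbers for stronger inhibition. Compound 2 shows the lowest of the two numbers; the nearest is compound 1, and the step of a 1.3-fold lower number from compound 1 to compound 2 (0.12 log units; within the scatter) lies within the scatter, so the two cannot be told apart.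

Compound 3 `N[C@]1(C(=O)O)[C@H]2[C@@H](C[C@H]1OCc1cccs1)[C@]2(F)C(=O)O` is the next member. It differs from compound 2 by thiophen-2-yl in place of 2,6-dichlorophenyl on a saturated chain carbon bound to an oxygen on a saturated carbon. Within the data shown here, the only measured step, from compound 1 to compound 2, exchanged one dichlorophenyl for another and changed little; it gives no direct guide to a thiophen-2-yl, a smaller ring of a different kind. Among the measured compounds shown here, with no comparable step on record, a modest loss of affinity seems the most likely outcome, with wide uncertainty. The estimate for compound 3 is therefore a step of a 3.5-fold higher number from compound 2 to compound 3 (0.54 log units; beyond the scatter) in this assay, giving an expected value of 15 nM, in a range from 4 nM to 60 nM.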

Compound 3, inhibition constant: 8.79 nM
Compound 3: the middle estimate sits 1.7-fold (0.23 log units) above what was measured; the range from low to high includes it.
By their numbers in this assay, from the lowest: compounds 2, 1 and 3 (each within the scatter of the next, the first and the last beyond it).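

In this assay the aryl group at this position need not be a dichlorophenyl at all. Thiophen-2-yl, a five-membered aromatic ring with no chlorine, gives a 2.0-fold higher number from compound 2 to compound 3 (0.31 log units; beyond the scatter) and a modest change, while the same exchange made on the other dichlorophenyl gives a 1.6-fold higher number from compound 1 to compound 3 (0.20 log units; within the scatter) and so cannot be told apart from it. This position therefore accepts a ring of a different size and kind with little change in the number, and nothing measured here explains why.

From the compounds shown here alone, whether an aromatic ring is needed on this oxygen-bound chain carbon stays open, since a plain ethyl chain in its place would test that directly. It is also unknown how an unsubstituted phenyl or a thiophen-3-yl would compare.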